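Swapping Fluoro for Amino on the Phenyl Ring

The source may hold more compounds than are shown below. What is called first, only, known or untested is meant among the compounds shown, and "the series" means these compounds.

In a functional assay on U-266 cells (Homo sapiens) for cytotoxicity, read by fluorescence and resazurin assay, with a stated time of 72 h (a higher number here means a weaker inhibitor, a lower number a stronger inhibitor), compound 2 `Nc1nc(Nc2ccc(S(N)(=O)=O)cc2)sc1C(=O)c1cccc(F)c1` gives 1500 nM and compound 1 `Nc1nc(Nc2ccc(S(N)(=O)=O)cc2)sc1C(=O)c1ccccc1[N+](=O)[O-]` gives 1800 nM and these two values lie within the usual scatter of each other. For the measured compounds named here, the one measured step is a 1.2-fold lower number from compound 1 to compound 2 (0.08 log units; within the scatter) with 3-fluorophenyl in place of 2-nitrophenyl on a carbonyl carbon. Going by the values given here, compound 3 `Nc1cccc(C(=O)c2sc(Nc3ccc(S(N)(=O)=O)cc3)nc2N)c1` differs from compound 2 by amino in place of fluoro on an aromatic carbon and no measured step covers this swap. Among the compounds with values here, that single small step is the only guide, so no step beyond the scatter is expected in this assay for this change. The estimated change is small (no change at the digits printed from compound 2 to compound 3 (within the scatter)). For compound 3 the estimate is 1500 nM with a range from 600 nM to 3800 nM expected.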

Compound 3, half-maximal inhibitory concentration: 5500 nM
Compound 3: the middle estimate sits 3.7-fold (0.56 log units) below what was measured, and the stated range ends below it.
By their numbers in this assay, from the lowest: compounds 2 and 1 (each within the scatter of the next); then compound 3.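

In this assay amino in place of fluoro brings a 3.7-fold higher number from compound 2 to compound 3 (0.56 log units; beyond the scatter) and so shows that this position on the phenyl ring can shift the number, which the earlier step within the scatter did not show. Replacing 2-nitrophenyl with 3-aminophenyl brings a 3.1-fold higher number from compound 1 to compound 3 (0.49 log units; beyond the scatter) and places compound 3 on the weaker side of both earlier compounds. Nothing measured here accounts for this rise. Going by these compounds, whether a hydroxyl or methoxy group in the same place would behave like amino or like fluoro remains open.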